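Methylselanyl in place of methylsulfanyl on the shared core

The source may hold more compounds than are shown below. What is called first, only, known or untested is meant among the compounds shown, and "the series" means these compounds.

Compound 3 `CSc1ccc(CNc2nc(SC)nc3ccccc23)cc1` carries methylsulfanyl both on the shared core and on the benzyl group. In a functional assay on CCRF-CEM cells (Homo sapiens) for cytotoxicity, read by MTT assay, with a stated time of 72 h (on this read-out higher numbers stand for weaker inhibition of growth and lower numbers for stronger inhibition of growth), compound 3 gives only a limit, > 100000 nM. Compound 1 `CSc1ccc(CNc2nc([SeH])nc3ccccc23)cc1`, with a selenol on the core, in this assay also gives only a limit, > 100000 nM. Within the data shown here, the one step measured at this position, a step that the two limits leave unreadable from compound 1 to compound 3, therefore has no readable size, both values sitting at the limit of > 100000 nM in this assay, at which 2 of the 3 values shown sit. Among the measured compounds shown here, compound 2 `C[Se]c1nc(NCc2ccccc2)c2ccccc2n1`, with methylselanyl on the core and an unsubstituted benzyl group, gives 61600 nM in this assay, the only number in the set.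

Compound 4 `CSc1ccc(CNc2nc([Se]C)nc3ccccc23)cc1` differs from compound 3 by a group of 2 heavy atoms (1 carbon, 1 selenium; no ring) in place of a group of 2 heavy atoms (1 carbon, 1 sulfur; no ring), on an aromatic carbon. For the measured compounds named here, no measured step covers this exchange directly. Going by the values given here, the value of compound 2 at 61600 nM shows that a methylselanyl group at this position can return a measurable number, but compound 2 and compound 4 also differ in the benzyl group, and no step between them is known. With compound 3 at its limit, neither direction nor size of the change can be read from the measured steps.

Compound 4 is expected near 90000 nM, with a range from 40000 nM to 200000 nM. This estimate rests on compound 2 giving 61600 nM. The estimated step is an at least 1.1-fold lower number from compound 3 to compound 4 (0.04 log units; that floor lies within the scatter), and a limit remains likely.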

Compound 4, concentration for total growth inhibition: 86900 nM
For compound 4 the middle estimate is 1.0-fold (0.02 log units) above the measured one; the range from low to high includes it.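

Compound 4 gives the methylselanyl-for-methylsulfanyl exchange on the shared core its first readable step in this assay, and that step is only a floor: an at least 1.1-fold lower number from compound 3 to compound 4 (0.06 log units; that floor lies within the scatter). Methyl in place of hydrogen on the selenium also now has a step, again only a floor: an at least 1.1-fold lower number from compound 1 to compound 4 (0.06 log units; that floor lies within the scatter). With methylselanyl on the core in both compounds, methylsulfanyl in place of hydrogen on an aromatic carbon of the benzyl group gives a 1.4-fold higher number from compound 2 to compound 4 (0.15 log units; within the scatter), so this pair shows no change in growth inhibition that stands clear of the scatter.

On these data alone, compound 1 and compound 3 each stand only as a limit, so how far the two floors lie from the real steps stays open: the limit of > 100000 nM in this assay, at which 2 of the 4 values shown sit. Also open, as far as these compounds go, is whether a longer chain on the selenium, such as ethyl, or an amine in place of the methylselanyl group on the shared core would return a number that differs from compound 4 by more than the scatter.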